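Bromophenyl for pyridinyl on an aminopyrrole core

The source may report more compounds than this note shows. Statements on the series, on what has been measured and on what is new or still open speak of the compounds shown alone.

Measured compounds:
compound 1 `N#Cc1cc(-c2ccccc2)n(-c2ccncc2)c1N`, 10700 nM
compound 2 `N#Cc1cc(-c2ccccc2)n(-c2cccc(Br)c2)c1N`, 13000 nM
compound 3 `Nc1c(-c2nc3ccccc3[nH]2)cc(-c2ccccc2)n1-c1ccncc1`, 1100 nM

In a functional assay on A549 cells (Homo sapiens) for cytotoxicity, read by resazurin assay, with a stated time of 72 h (on this read-out higher numbers stand for weaker inhibition and lower numbers for stronger inhibition), compound 1 gives 10700 nM and compound 2 gives 13000 nM. The change between them is 3-bromophenyl in place of pyridin-4-yl on an aromatic nitrogen, and the step it made was a 1.2-fold higher number from compound 1 to compound 2 (0.08 log units; within the scatter). Compound 3 carries a different group on its core: the difference from compound 1 is 1H-benzimidazol-2-yl in place of cyano on an aromatic carbon, and the step was a 9.7-fold lower number from compound 1 to compound 3 (0.99 log units; beyond the scatter). In this assay compound 3 gives 1100 nM.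

Compound 4 `Nc1c(-c2nc3ccccc3[nH]2)cc(-c2ccccc2)n1-c1cccc(Br)c1` has not been measured. It differs from compound 3 by 3-bromophenyl in place of pyridin-4-yl on an aromatic nitrogen, the same kind of change as that from compound 1 to compound 2; the surroundings differ in that the place is two ring bonds from the ring atom that bears a 1H-benzimidazol-2-yl group rather than a cyano group. Since the earlier instance gave a 1.2-fold higher number from compound 1 to compound 2 (0.08 log units; within the scatter), a similarly small step is expected here, a 1.2-fold higher number from compound 3 to compound 4 (0.07 log units; within the scatter). Compound 4 is therefore estimated at 1300 nM in this assay, with a likely range of 500 nM to 3500 nM.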

Compound 4, half-maximal inhibitory concentration: 13500 nM
Beside the measured number, compound 4's estimate is 10-fold (1.02 log units) below it, outside the stated range (above it).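

In this assay, 3-bromophenyl in place of pyridin-4-yl did not carry over from one core to the other, as on the core bearing 1H-benzimidazol-2-yl it gave a 12-fold higher number from compound 3 to compound 4 (1.09 log units; beyond the scatter), and the two instances differ: the same change on two cores in this assay, a 1.2-fold higher number (0.08 log units; within the scatter) from compound 1 to compound 2 and a 12-fold higher number (1.09 log units; beyond the scatter) from compound 3 to compound 4, 10-fold (1.00 log units) apart, beyond the scatter of two such steps. Read the other way, 1H-benzimidazol-2-yl in place of cyano gave a 1.0-fold higher number from compound 2 to compound 4 (0.02 log units; within the scatter), so the lower number seen with pyridin-4-yl did not appear with 3-bromophenyl: the same change on two cores in this assay, a 9.7-fold lower number (0.99 log units; beyond the scatter) from compound 1 to compound 3 and a 1.0-fold higher number (0.02 log units; within the scatter) from compound 2 to compound 4, 10-fold (1.00 log units) apart, beyond the scatter of two such steps. Across these four compounds the effect of each change depends on the group at the other place, but this does not show why, nor whether the dependence extends to other groups at either place.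

The compounds shown leave open whether the lower number of compound 3 is tied to pyridin-4-yl itself or would also appear with another group on the aromatic nitrogen, such as a plain phenyl or a cyclohexyl. They also leave open how a carboxylic acid or an amide in place of 1H-benzimidazol-2-yl would behave with each of these two groups.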